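Dimethylamino for Methoxy on Two Related Cores

A few compounds are considered here, and "the series" means these few. Any claim that something is new, unique, unknown or untested is made for them only; others in the source may bear on it.

Compound 1 `COc1ccc(/C=C/c2ccc3ccccc3c2)cc1` and compound 2 `CN(C)c1ccc(/C=C/c2ccc3ccccc3c2)cc1` share one core. In a functional assay on A549 cells (Homo sapiens) for inhibition (on this read-out lower numbers stand for stronger inhibition and higher numbers for weaker inhibition), compound 1 gives > 5000 nM, which is a limit of the assay rather than a number. Compound 2 gives 3660 nM. The change between them is dimethylamino in place of methoxy on an aromatic carbon, and the step it made is an at least 1.3-fold lower number from compound 1 to compound 2 (0.13 log units; that floor lies within the scatter).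

Compound 3 `COc1c([N+](=O)[O-])cc(/C=C/c2ccc3ccccc3c2)cc1[N+](=O)[O-]` carries the same methoxy on a core whose difference from that of compound 1 is not broken down here. In this assay compound 3 gives > 5000 nM, again a limit. Compound 4 `CN(C)c1c([N+](=O)[O-])cc(/C=C/c2ccc3ccccc3c2)cc1[N+](=O)[O-]` has not been measured; it differs from compound 3 by dimethylamino in place of methoxy on an aromatic carbon. The place is not identical, since here the carbon is ortho to two nitro groups (3 heavy atoms each), so this is the same kind of change, not the same change. The comparison rests on (the limit of > 5000 nM in this assay, at which 2 of the 3 values shown sit), which leaves the size of the earlier step uncertain.

The step from compound 3 to compound 4 is expected to resemble the earlier step from compound 1 to compound 2. The step expected here is an at least 1.2-fold lower number from compound 3 to compound 4 (0.09 log units; that floor lies within the scatter). Compound 4 is therefore expected to give about 4000 nM, between 1500 nM and 8000 nM.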

Compound 4, half-maximal inhibitory concentration: > 5000 nM
Compound 4 ended at the assay's limit; the forecaster's own chance of this, stated with the estimate: 50%; middle value at least 1.2-fold (0.09 log units) from the limit.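

In this assay compound 4 gives > 5000 nM, a limit of the assay and not a number. No step between compound 3 and compound 4 can be read, because both stand at a limit: the limit of > 5000 nM in this assay, at which 3 of the 4 values shown sit.

The compounds shown leave open whether dimethylamino in place of methoxy changes the number at all on the core of compound 3.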